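Tetrazole for Carboxylic Acid on the Aryl Ether Chain

This account rests on a few compounds, and the source may have more. Where it says the series, first, only, none or still open, it means among the compounds named here.

Compound 1 `CCc1cc(C(C)=O)c(O)cc1OCCCC(C)(C)C#N`: 13%
Compound 2 `CCc1cc(C(C)=O)c(O)cc1OCCCCC(C)(C)C#N`: 5%
Compound 3 `CCc1cc(C(C)=O)c(O)cc1OCCCCCC(C)(C)C(=O)O`: 20%

In an assay on isolated protein for binding affinity to leukotriene B4 receptor (Homo sapiens), tested at 0.1 uM (a higher number here means more inhibition at the concentration tested (going by the name of the read-out), a lower number less inhibition), compound 3 gives the highest of the three numbers. Its lead over compound 1 is a number 7 percentage points higher from compound 1 to compound 3 (within the scatter), and over compound 2 it is a number 15 percentage points higher from compound 2 to compound 3 (beyond the scatter). Compound 4 `CCc1cc(C(C)=O)c(O)cc1OCCCC(C)(C)c1nnn[nH]1` changes compound 3 in one place: 1-(1H-tetrazol-5-yl)-1-methylethyl in place of 3-carboxy-3-methylbutyl on a saturated chain carbon, three bonds along the chain from an oxygen on an aromatic ring. Among the compounds with values here, no measured step here swaps a carboxylic acid for a tetrazole; the measured steps only vary the chain and the nitrile against the acid, as in a number 8 percentage points lower from compound 1 to compound 2 (within the scatter) and a number 15 percentage points higher from compound 2 to compound 3 (beyond the scatter). With the chain length of compound 4 matching compound 1 and the acid-like end kept, compound 4 is expected to stay close to compound 3, a step of no change at the digits printed from compound 3 to compound 4 (within the scatter). The estimate for compound 4 is therefore 20%, within 5% to 40%.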

Compound 4, a percentage reported as inhibition, at one concentration (the size of the read-out at that concentration, not a potency): 28%
For compound 4 the middle estimate is 8 percentage points below the measured one; the range from low to high includes it.
By their numbers in this assay, from the lowest: compounds 2, 1, 3 and 4 (each within the scatter of the next, the first and the last beyond it).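

In this assay putting 1H-tetrazol-5-yl in place of cyano on the same chain gives a number 15 percentage points higher from compound 1 to compound 4 (beyond the scatter) and so clears the scatter, while the comparison with the longer nitrile chain gives a number 23 percentage points higher from compound 2 to compound 4 (beyond the scatter) in the same direction. Against the carboxylic acid, the change gives a number 8 percentage points higher from compound 3 to compound 4 (within the scatter) and so does not separate the two end groups, although this step alters the chain as well as the end group. Nothing available here explains these steps.

The compounds shown leave open how a carboxylic acid would compare with the tetrazole on the chain of compound 4. They also leave open whether an amide at that chain end would keep the number of compound 4.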